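Losing the boron-bearing group from compound 1

The compounds below may be only part of what the source reports. "The series", "measured", "known", "first", "only" and "open" are said of these compounds alone.

Measured in a functional assay on PANC-1 cells (Homo sapiens) for cytotoxicity, read by MTT assay, with a stated time of 48 h; a higher number here means a weaker inhibitor, a lower number a stronger inhibitor:
Compound 1 `O=C(c1ccc2cccc(OCc3ccc(B(O)O)cc3)c2n1)N1CCC(Oc2no[n+]([O-])c2S(=O)(=O)c2ccccc2)CC1`: 16600 nM
Compound 2 `CC1(C)OB(c2ccc(COc3cccc4ccc(C(=O)N5CCC(Oc6no[n+]([O-])c6S(=O)(=O)c6ccccc6)CC5)nc34)cc2)OC1(C)C`: 13200 nM

Compound 1 at 16600 nM and compound 2 at 13200 nM lie within the scatter of each other. Compound 3 `O=C(c1ccc2cccc(O)c2n1)N1CCC(Oc2no[n+]([O-])c2S(=O)(=O)c2ccccc2)CC1`, not yet measured, departs from compound 1 by this change: a hydrogen atom in place of a group of 10 heavy atoms (7 carbon, 1 boron, 2 oxygen; one six-membered aromatic ring of carbon only), on an oxygen on an aromatic ring. Within the data shown here, the only measured step, a 1.3-fold lower number from compound 1 to compound 2 (0.10 log units; within the scatter), alters just the boron end of that group, so it bears only partly and the loss of the whole group remains untested. A small move toward a lower number in this assay is expected, not clearly beyond the scatter. The estimate amounts to a 1.8-fold lower number from compound 1 to compound 3 (0.27 log units; within the scatter). Compound 3 is expected at 9000 nM, within an estimated range of 2500 nM to 30000 nM.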

Compound 3, half-maximal inhibitory concentration: 9050 nM
The estimate for compound 3 lay 1.0-fold (0.00 log units) below the measured number; measured number inside the range.
By their numbers in this assay, from the lowest: compounds 3, 2 and 1 (each within the scatter of the next).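

In this assay, the step of a 1.8-fold lower number from compound 1 to compound 3 (0.26 log units; within the scatter) stays within the scatter even though the entire group on the oxygen is lost, not just its boron end. The aromatic ring and the boron together can therefore be absent from this oxygen with no change beyond the scatter in this assay. No measurement offered here speaks to the reason for this result.

From the compounds shown here alone, whether a methyl group, or a longer chain ending in an amine, on that oxygen would move the number beyond the scatter remains open. So does whether this position can affect the number at all.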